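Aryl alkyl variation: isopropyl to ethyl

The source may hold more compounds than are shown below. What is called first, only, known or untested is meant among the compounds shown, and "the series" means these compounds.

Compound 2 `CC(C)c1ccc(N2C(=O)C=CC2OCC(F)(F)F)cc1` carries an isopropyl group on its aryl ring. In a functional assay on A549 cells (Homo sapiens) for inhibition (on this read-out lower numbers stand for stronger inhibition and higher numbers for weaker inhibition), compound 2 gives 9570 nM, the highest of the two numbers available; compound 1 `O=C1C=CC(OCC(F)(F)F)N1c1cc(Cl)cc(Cl)c1` gives 1630 nM, and this gap lies beyond the usual scatter. Compound 3 `CC(C)NC1CC(=O)N(c2ccc(F)c(Cl)c2)C1OCC(F)(F)F` returns only a limit in this assay, > 100000 nM, namely (the limit of > 100000 nM in this assay, at which 1 of the 3 values shown sits). Compound 4 `CCc1ccc(N2C(=O)C=CC2OCC(F)(F)F)cc1` has yet to be measured. Its difference from compound 2 is hydrogen in place of methyl on a saturated chain carbon bound to an aromatic carbon and a saturated chain carbon. For the measured compounds named here, no comparable step among the measured compounds exists. The expected step from compound 2 to compound 4 is a 1.2-fold lower number from compound 2 to compound 4 (0.08 log units; within the scatter), none beyond the scatter. Compound 4 is therefore estimated at 8000 nM in this assay, within 2500 nM to 30000 nM.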

Compound 4, half-maximal inhibitory concentration: 8090 nM
Beside the measured number, compound 4's estimate is 1.0-fold (0.00 log units) below it; measured number inside the range.
By their numbers in this assay, from the lowest: compound 1; then compounds 4 and 2 (each within the scatter of the next). At a limit, above all of these: compound 3.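

Isopropyl to ethyl on the aryl ring gives a 1.2-fold lower number from compound 2 to compound 4 (0.07 log units; within the scatter) in this assay, the only step shown between compounds differing in one place. At this saturated chain carbon, hydrogen can therefore replace methyl with no difference that stands out from the scatter. This holds for these two alkyl groups only.

Going by these compounds, whether a single methyl, a longer chain, an amine or a carboxylic acid on the aryl ring would read alike stays open. Nothing shown here bears on why isopropyl and ethyl read alike.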